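This account rests on a few compounds, and the source may have more. Where it says the series, first, only, none or still open, it means among the compounds named here.

Measured in a functional assay on SK-MEL-5 cells (Homo sapiens) for inhibition, read by sulforhodamine B assay, with a stated time of 48 h; on this read-out higher numbers stand for weaker inhibition of growth and lower numbers for stronger inhibition of growth:
- compound 1 `COc1cc(-c2nn(-c3cccc(NC(=O)c4cccc(C(F)(F)F)c4)c3)cc2-c2ccncc2)ccc1Cl`: 2470 nM
- compound 2 `COc1cc(-c2nn(-c3cccc(NC(=O)Nc4ccc(Cl)c(Cl)c4)c3)cc2-c2ccncc2)ccc1Cl`: 1490 nM
- compound 3 `COc1cc(-c2nn(-c3cccc(NC(=O)Nc4cccc(C(F)(F)F)c4)c3)cc2-c2ccncc2)ccc1Cl`: 1390 nM

Compound 3 sits within the scatter of compound 1 and compound 2, so the three measured compounds are not separated on these numbers. Compound 4 `COc1cc(-c2nn(-c3cccc(NC(=O)Nc4ccc(Cl)c(C(F)(F)F)c4)c3)cc2-c2ccncc2)ccc1Cl` differs from compound 3 by chloro in place of hydrogen on an aromatic carbon. The closest evidence is a 1.1-fold lower number from compound 2 to compound 3 (0.03 log units; within the scatter), a change on the same terminal aromatic ring that stays within the scatter. The carbonyl-side changes, a 1.7-fold lower number from compound 1 to compound 2 (0.22 log units; within the scatter) and a 1.8-fold lower number from compound 1 to compound 3 (0.25 log units; within the scatter), also stay within it. No step beyond the scatter is therefore expected in this assay, and the expected change is a 1.1-fold lower number from compound 3 to compound 4 (0.03 log units; within the scatter). Compound 4 is estimated at 1300 nM, with an expected range of 700 nM to 2400 nM.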

Compound 4, concentration for total growth inhibition: 2890 nM
The estimate for compound 4 lay 2.2-fold (0.35 log units) below the measured number, and the stated range ends below it.
By their numbers in this assay, from the lowest: compounds 3, 2, 1 and 4 (each within the scatter of the next, the first and the last beyond it).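

Going by these compounds alone, on the 3-(trifluoromethyl)phenyl ring, chloro ortho to a trifluoromethyl group gives the first step beyond the scatter in this assay (a 2.1-fold higher number from compound 3 to compound 4 (0.32 log units; beyond the scatter)), a modest loss of growth inhibition. Trifluoromethyl in place of chloro stays within the scatter (a 1.9-fold higher number from compound 2 to compound 4 (0.29 log units; within the scatter)), as does the change from the amide (a 1.2-fold higher number from compound 1 to compound 4 (0.07 log units; within the scatter)). No measurement at hand accounts for the step from hydrogen to chloro.

Open, from the compounds shown here alone, is whether fluoro, methyl or methoxy in place of that hydrogen gives a step of similar size. Also open, going by these compounds, is whether chloro at this position has the same result on the amide of compound 1.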